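Chloro for methoxy on the sulfonyl aryl in compound 4

A few compounds are considered here, and "the series" means these few. Any claim that something is new, unique, unknown or untested is made for them only; others in the source may bear on it.

Measured so far:
- compound 1, `Cc1ccc(S(=O)(=O)Nc2ccc3c(c2)c(Cc2ccc(F)cc2)cn3CCC(=O)O)cc1`: in a functional assay on aorta for antagonist activity at thromboxane A2 receptor (Rattus norvegicus) (a higher number here means weaker binding, a lower number tighter binding), compound 1 gives 0.269 nM
- compound 2, `COc1ccc(S(=O)(=O)Nc2ccc3c(c2)c(Cc2ccc(F)cc2)cn3CCC(=O)O)cc1`: in this assay compound 2 gives 0.174 nM
- compound 3, `Cc1c(Cn2ccnc2)c2cc(NS(=O)(=O)c3ccc(F)cc3)ccc2n1CCC(=O)O`: in this assay compound 3 gives 3800 nM

Compound 2 has the lowest of the three numbers. Its nearest neighbour is compound 1, and that step, a 1.5-fold lower number from compound 1 to compound 2 (0.19 log units; within the scatter), is within the scatter, so the two cannot be ordered. Among the measured compounds shown here, compound 3 differs from compound 2 in several places at once and sits far off; its value shows only that those combined changes cost a great deal, and no single step can be read from it.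

Compound 4, `O=C(O)CCn1cc(Cc2ccc(F)cc2)c2cc(NS(=O)(=O)c3ccc(Cl)cc3)ccc21`, differs from compound 2 in one place: chloro in place of methoxy on an aromatic carbon.

For the measured compounds named here, the only measured step at this position is the one from compound 1 to compound 2, methoxy for methyl, and it stayed within the scatter. Going by the values given here, a halogen at the same place has no precedent, so the expectation rests on that one step alone: the sulfonyl aryl tolerated the swap of two small groups without a detectable shift, and a chloro is expected to behave similarly. A step of about a 1.4-fold higher number from compound 2 to compound 4 (0.16 log units; within the scatter) is expected, that is, no change beyond the scatter.

Compound 4 is therefore estimated at 0.25 nM, with a range from 0.08 nM to 0.8 nM.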

Compound 4, dissociation constant: 0.234 nM
Beside the measured number, compound 4's estimate is 1.1-fold (0.03 log units) above it; the range from low to high includes it.
By their numbers in this assay, from the lowest: compounds 2, 4 and 1 (each within the scatter of the next); then compound 3.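

In this assay, chloro in place of methoxy gives a 1.3-fold higher number from compound 2 to compound 4 (0.13 log units; within the scatter) and chloro in place of methyl gives a 1.1-fold lower number from compound 1 to compound 4 (0.06 log units; within the scatter), so a halogen now joins the two groups compared earlier, and methyl, methoxy and chloro at this place cannot be ordered. The single chlorine atom carries no hydrogen-bond acceptor by the count, whereas the methoxy carries one, so that acceptor is not needed for a value in the range of compound 2 and compound 1 in this series. Nothing on hand bears on why these three groups read alike.

The compounds shown leave open how far this flat response reaches: an amine, a carboxylic acid or a longer alkoxy chain at this place could read quite differently. They also leave open whether the three groups would still read alike at another carbon of the same ring, since all of them sit at the one place, on an aromatic carbon para to a large group.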